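This account rests on a few compounds, and the source may have more. Where it says the series, first, only, none or still open, it means among the compounds named here.

Measured compounds in a functional assay on A549 cells (Homo sapiens) for inhibition, read by sulforhodamine B assay, with a stated time of 48 h; a lower number here means a stronger inhibitor of growth, a higher number a weaker inhibitor of growth:
- compound 1 `COC(=O)[C@@]1(C)CCC=C2[C@@H]1CC[C@@H](C)[C@]2(C)Cc1c(C)[nH]c2ccccc12`, compound 1 gives 15000 nM
- compound 2 `COC(=O)[C@@]1(C)CCC=C2[C@@H]1CC[C@@H](C)[C@]2(C)Cc1c(C)[nH]c2ccc(C)cc12`, compound 2 gives 26000 nM
- compound 3 `COC(=O)[C@@]1(C)CC[C@@H]2C3=C1CC[C@@H](C)[C@]3(C)Cc1c2[nH]c2ccccc12`, compound 3 gives 4600 nM

Compound 3 carries the lowest number of the three; its difference from the core of compound 1 is not broken down here. The step of a 1.7-fold higher number from compound 1 to compound 2 (0.24 log units; within the scatter) came from methyl in place of hydrogen on an aromatic carbon. Compound 4 `COC(=O)[C@@]1(C)CC[C@@H]2C3=C1CC[C@@H](C)[C@]3(C)Cc1c2[nH]c2c(C)cccc12` is not yet measured; it differs from compound 3 by methyl in place of hydrogen on an aromatic carbon. This is the same kind of change as from compound 1 to compound 2, but the ring is part of a fused or bridged system of five rings rather than two, and the place is ortho and meta to a fused ring rather than meta and para. Because a 1.7-fold higher number from compound 1 to compound 2 (0.24 log units; within the scatter) lay within the scatter, the step of a 1.4-fold higher number from compound 3 to compound 4 (0.15 log units; within the scatter) is expected to be similarly small. Compound 4 is estimated at 6500 nM in this assay.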

Compound 4, concentration for 50% growth inhibition: 16000 nM
Estimate against measurement, compound 4: 2.5-fold (0.39 log units) below; the measured number lies above the stated range.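

In this assay, methyl in place of hydrogen on an aromatic carbon gives a 3.5-fold higher number from compound 3 to compound 4 (0.54 log units; beyond the scatter). Set beside the earlier step on the core of compound 1, the change shows no detectable difference between the two cores: the same change on two cores in this assay, a 1.7-fold higher number (0.24 log units; within the scatter) from compound 1 to compound 2 and a 3.5-fold higher number (0.54 log units; beyond the scatter) from compound 3 to compound 4, 2.0-fold (0.30 log units) apart, within the scatter of two such steps. This rests on one pair per core, with the methyl at a different place in each, so it does not separate the effect of the core from that of the place and gives no general rule for carrying the change across the series.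

Still open, on these data alone, is how other groups on this aromatic ring, such as fluorine or methoxy, would behave. Also open, as far as these compounds go, is how replacing the methyl ester with a carboxylic acid or an amide would affect growth inhibition.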